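A Methyl-Branched Alcohol Replaces a Straight Chain End

The source may hold more compounds than are shown below. What is called first, only, known or untested is meant among the compounds shown, and "the series" means these compounds.

Of the compounds shown here, three that share one core have been tested in an assay on HEK293 cells for agonist activity at Toll-like receptor 8 (Homo sapiens), read by spectrophotometry; on this read-out higher numbers stand for an effect only at larger amounts of compound and lower numbers for an effect already at smaller amounts. Compound 1 `CCCCNc1nc(N)nc(C)c1CCCCO` gives 1310 nM in this assay, the second highest of the three numbers. Compound 3 `CCCCNc1nc(N)nc(C)c1CCCn1ccc2ccccc21` gives 1100 nM, which lies within the scatter of the number for compound 1, so the two cannot be told apart. Compound 2 `CCCCNc1nc(N)nc(C)c1C#CCN1CCCCC1` gives 3790 nM, a higher number that lies beyond the scatter, so compound 2 acts only at larger amounts than compound 1.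

Compound 4 `CCCCNc1nc(N)nc(C)c1CCC(C)(C)O` has not yet been measured. It differs from compound 1 in one place: 1-hydroxy-1-methylethyl in place of 2-hydroxyethyl on a saturated chain carbon, two bonds along the chain from an aromatic carbon. Among the measured compounds shown here, no pair of compounds measured so far differs in just this way, so nothing among the measured numbers shows how such a change moves the read-out. The step of a 1.2-fold higher number from compound 1 to compound 4 (0.09 log units; within the scatter) is therefore expected to be small, most likely within the scatter, with no clear direction. Compound 4 is estimated at 1600 nM, within a range from 550 nM to 4700 nM.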

Compound 4, half-maximal effective concentration: 3140 nM
The estimate for compound 4 lay 2.0-fold (0.29 log units) below the measured number; the range from low to high includes it.
By their numbers in this assay, from the lowest: compounds 3 and 1 (each within the scatter of the next); then compounds 4 and 2 (each within the scatter of the next).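

Among the compounds shown here, this is the first step measured at this position, and it shows that the end of the chain matters in this assay: 1-hydroxy-1-methylethyl in place of 2-hydroxyethyl gives a 2.4-fold higher number from compound 1 to compound 4 (0.38 log units; beyond the scatter), a modest step beyond the scatter. Compound 4 therefore needs larger amounts of compound than compound 1 for the same effect, even though the two groups have the same hydrogen-bond donor and acceptor counts and neither has a ring or a net charge. Nothing available explains why this step occurs.

The compounds shown leave open how a chain end carrying only one extra methyl group would read. They also leave open whether an amine or a carboxylic acid in place of the hydroxyl group would move the number further, or bring it back down.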